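Following One Ether Swap at the Assay Limit

The source may report more compounds than this note shows. Statements on the series, on what has been measured and on what is new or still open speak of the compounds shown alone.

Compound 2 `CC(C)[C@H](NC(=O)COc1cccc2ccccc12)C(=O)N[C@@H](CC(=O)O)C(=O)COn1nnc2ccccc21` is one of two measured compounds built on a shared core. In a functional assay on Jurkat cells (Homo sapiens) for inhibition (on this read-out lower numbers stand for stronger inhibition and higher numbers for weaker inhibition), compound 2 gives > 200000 nM, which is a limit of the assay and not a number. Compound 1 `CC(C)[C@H](NC(=O)COc1cccc2ccccc12)C(=O)N[C@@H](CC(=O)O)C(=O)CSc1nc2ccccc2o1` gives in this assay > 200000 nM, which is also a limit. Going by the values given here, the one measured step, a step that the two limits leave unreadable from compound 1 to compound 2, sits on a saturated chain carbon bound to a carbonyl carbon and cannot be read, since the limit of > 200000 nM in this assay, at which 2 of the 2 values shown sit, holds both values. Compound 3 `CC(C)[C@H](NC(=O)COc1cccc2ccccc12)C(=O)N[C@@H](CC(=O)O)C(=O)COc1cc(C(F)(F)F)ncn1` differs from compound 2 by a group of 10 heavy atoms (5 carbon, 2 nitrogen, 3 fluorine; one six-membered aromatic ring with 2 hetero atoms) in place of a group of 9 heavy atoms (6 carbon, 3 nitrogen; one five-membered aromatic ring with 3 hetero atoms, one six-membered aromatic ring of carbon only), on an oxygen on a saturated carbon, a change on an oxygen on a saturated carbon. Among the compounds with values here, no measured step bears on this change in a readable way, and the two known values give no direction. One therefore expects compound 3 to remain near the limit, an expected step of a number no higher from compound 2 to compound 3 (the limit leaves the size open) of no readable size. The estimate for compound 3 in this assay is 200000 nM, in a range from 50000 nM to 1000000 nM.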

Compound 3, half-maximal inhibitory concentration: > 200000 nM
Compound 3 ended at the assay's limit (the forecaster's own chance of this, stated with the estimate: 80%); the middle value sits exactly at the limit.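

Compound 3 gives > 200000 nM in this assay, which is a limit of the assay and not a number. The steps from compound 1 and compound 2 to compound 3 therefore cannot be read: the limit of > 200000 nM in this assay, at which 3 of the 3 values shown sit.

The compounds shown leave open whether any group at this place on the shared core gives a readable value.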